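The source may hold more compounds than are shown below. What is called first, only, known or untested is meant among the compounds shown, and "the series" means these compounds.

Notes on the sulfonamide series, read in a functional assay on P388 cells (Mus musculus) for antiproliferative activity, read by colorimetric assay and MTT assay; a lower number here means a stronger inhibitor, a higher number a weaker inhibitor.

Compound 1 `O=[N+]([O-])c1ccc(S(=O)(=O)Nc2cccc3cc[nH]c23)cc1` gives 8.2 ug/mL in this assay. Compound 2 `O=[N+]([O-])c1ccc(S(=O)(=O)Nc2cccc3cc(Cl)[nH]c23)cc1` carries the change chloro in place of hydrogen on an aromatic carbon and gives 21 ug/mL in this assay; the step of a 2.6-fold higher number from compound 1 to compound 2 (0.41 log units; beyond the scatter) is the only measured case of this change in the set.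

Compound 3 `N#Cc1ccc(S(=O)(=O)Nc2ccc(Cl)c3cc[nH]c23)cc1` is built on a different core; how its core differs from the core of compound 1 is not broken down here. In this assay compound 3 gives 1.8 ug/mL, the lowest number among the three measured compounds, with compound 1 nearest and compound 2 furthest.

Compound 4 `N#Cc1ccc(S(=O)(=O)Nc2ccc(Cl)c3c(Cl)c[nH]c23)cc1` has not yet been measured. It differs from compound 3 by chloro in place of hydrogen on an aromatic carbon. This is the same kind of change as that from compound 1 to compound 2, not the same: there the chloro entered next to the ring nitrogen, here it enters two ring bonds from the ring nitrogen. With one measured case on another core and a different place on the five-membered ring, the expectation rests on the step of a 2.6-fold higher number from compound 1 to compound 2 (0.41 log units; beyond the scatter) alone and is held loosely. From compound 3 to compound 4 a step of about a 2.5-fold higher number from compound 3 to compound 4 (0.40 log units; beyond the scatter) is expected in this assay, a modest rise. Compound 4 is therefore estimated at 4.5 ug/mL in this assay, with a range from 1.5 ug/mL to 13 ug/mL.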

Compound 4, half-maximal inhibitory concentration: 0.59 ug/mL
The estimate for compound 4 lay 7.6-fold (0.88 log units) above the measured number; measured number outside the range, below it.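

In this assay, chloro in place of hydrogen on an aromatic carbon gives a 3.1-fold lower number from compound 3 to compound 4 (0.48 log units; beyond the scatter), so the change does not carry over from one core to the other with a single direction or a single size: the same change on two cores in this assay, a 2.6-fold higher number (0.41 log units; beyond the scatter) from compound 1 to compound 2 and a 3.1-fold lower number (0.48 log units; beyond the scatter) from compound 3 to compound 4, 7.8-fold (0.89 log units) apart, beyond the scatter of two such steps. This result warns against transferring the step from compound 1 to compound 2 to other cores in the series, but it does not show whether the core or the place of the chloro sets the direction, since the two steps differ in both: in compound 4 the chloro stands two ring bonds from the ring nitrogen, and in compound 2 it stands elsewhere on the five-membered ring. Among these compounds, with only one step on each core, neither direction can be taken as a rule for that core, and the pair gives no cause for the reversal.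

Still open, from the compounds shown here alone, is whether chloro at the place two ring bonds from the ring nitrogen lowers the number on the core of compound 1 as well, which would separate core from place. Also open, going by these compounds, is whether a bromo or a methyl at that place follows chloro, and whether an amine or a carboxylic acid in place of the nitrile keeps the low number of compound 4.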